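A few compounds are considered here, and "the series" means these few. Any claim that something is new, unique, unknown or untested is made for them only; others in the source may bear on it.

Working notes on the series. All compounds share one core and differ only in the group on a saturated chain carbon bound to an aromatic nitrogen. Compound 2 `CCCc1nc(C)c2cnn(C)c(=O)n12` carries a methyl there and in a functional assay for inhibition, with Homo sapiens as the target (a lower number here means a stronger inhibitor, a higher number a weaker inhibitor), compound 2 gives 20000 nM. Compound 3 `C=CCn1ncc2c(C)nc(CCC)n2c1=O` carries an allyl and in this assay compound 3 gives 40000 nM; of the two numbers shown it is the larger, but the step of a 2.0-fold higher number from compound 2 to compound 3 (0.30 log units; within the scatter) lies within the scatter. Compound 1 `CCCc1nc(C)c2cnn(CC3CC3)c(=O)n12` carries a cyclopropylmethyl. In this assay compound 1 reaches only > 48000 nM, which is a limit of the assay and not a number. The steps of an at least 2.4-fold lower number from compound 1 to compound 2 (0.38 log units; beyond the scatter) and an at least 1.2-fold lower number from compound 1 to compound 3 (0.07 log units; that floor lies within the scatter) are floors only, because of the limit of > 48000 nM in this assay, at which 1 of the 3 values shown sits.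

Compound 4 `CCCc1nc(C)c2cnn(CC)c(=O)n12` is not yet measured in this assay. Against compound 3 the change is methyl in place of vinyl on a saturated chain carbon bound to an aromatic nitrogen. The step that bears on it is a 2.0-fold higher number from compound 2 to compound 3 (0.30 log units; within the scatter), which stayed within the scatter; the steps from compound 1 give only floors. For compound 4 no step beyond the scatter is therefore expected in this assay, the estimated step being a 1.3-fold lower number from compound 3 to compound 4 (0.12 log units; within the scatter). Compound 4 is expected at 30000 nM, between 12000 nM and 70000 nM.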

Compound 4, half-maximal inhibitory concentration: > 48000 nM
Compound 4: only a limit was reported (the forecaster's own chance of this, stated with the estimate: 25%); middle value at least 1.6-fold (0.20 log units) from the limit.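

In this assay compound 4 gives only > 48000 nM, which is a limit of the assay and not a number. The ethyl already moves the number beyond the scatter, with an at least 2.4-fold higher number from compound 2 to compound 4 (0.38 log units; beyond the scatter), so the loss at this place is not confined to cyclopropylmethyl; the step of an at least 1.2-fold higher number from compound 3 to compound 4 (0.07 log units; that floor lies within the scatter) remains a floor within the scatter, which leaves allyl and ethyl unordered, and compound 3 goes against a plain fall-off beyond methyl, since it stays within the scatter of compound 2. The step between compound 1 and compound 4 cannot be read, because both sit at the same limit: the limit of > 48000 nM in this assay, at which 2 of the 4 values shown sit.

As far as these compounds go, the true size of the loss with ethyl stays open. Also open, from the compounds shown here alone, is whether a chain ending in an amine, a hydroxyl or a carboxylic acid would behave like the carbon-only groups at this place.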